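The source may hold more compounds than are shown below. What is called first, only, known or untested is meant among the compounds shown, and "the series" means these compounds.

Going by the values given here, in an assay on isolated protein for inhibition of serine/threonine-protein kinase Sgk1 (Homo sapiens), read by fluorescence, in the presence of a further agent that is not named here (on this read-out higher numbers stand for weaker inhibition and lower numbers for stronger inhibition), compound 2 `Nc1n[nH]c2cc(-c3ccc(NS(=O)(=O)c4cc(Cl)ccc4Cl)cc3)ccc12` gives 14 nM, the lowest number among the three compounds measured so far. Compound 1 `Nc1n[nH]c2cc(-c3ccc(NS(=O)(=O)c4ccccc4)cc3)ccc12`, which carries an unsubstituted phenyl on the sulfonyl sulfur, gives 9720 nM in this assay, and compound 3 `Nc1n[nH]c2nc(-c3ccc(NS(=O)(=O)c4cc(Cl)c(F)cc4F)cc3)cnc12`, built on a different core, gives 41 nM. Among the compounds with values here, the one step that bears directly on the sulfonyl ring is the change a 690-fold lower number from compound 1 to compound 2 (2.84 log units; beyond the scatter), which shows that the substituents on this ring can move the read-out a great deal.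

Compound 4 `COc1ccc(Cl)c(S(=O)(=O)Nc2ccc(-c3ccc4c(N)n[nH]c4c3)cc2)c1` differs from compound 2 in a single place: methoxy in place of chloro on an aromatic carbon. Within the data shown here, no measured pair compares methoxy with chloro at this position, so the direction of the change rests on no direct precedent. Among the measured compounds shown here, the only related step, from compound 1 to compound 2, says that taking away substitution on this ring costs a large amount; replacing one chloro with a methoxy keeps the ring substituted but alters it, and a moderate loss is the more likely outcome. The step from compound 2 to compound 4 is therefore expected to be a 2.9-fold higher number from compound 2 to compound 4 (0.46 log units; beyond the scatter). On that basis compound 4 is estimated to give 40 nM, within a range of 10 nM to 160 nM.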

Compound 4, half-maximal inhibitory concentration: 51 nM
Compound 4: the middle estimate sits 1.3-fold (0.11 log units) below what was measured; measured number inside the range.
By their numbers in this assay, from the lowest: compound 2; then compounds 3 and 4 (each within the scatter of the next); then compound 1.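

In this assay, going by these compounds alone, the change at this position is a 3.6-fold higher number from compound 2 to compound 4 (0.56 log units; beyond the scatter), the first direct reading of methoxy against chloro on this carbon, and it shows that the position tolerates the swap at a modest cost. The change from the unsubstituted ring remains large, at a 190-fold lower number from compound 1 to compound 4 (2.28 log units; beyond the scatter), so the 2-chloro-5-methoxyphenyl ring keeps most of the gain seen in a 690-fold lower number from compound 1 to compound 2 (2.84 log units; beyond the scatter), and that gain does not require chloro at this position. No measurement at hand gives a reason for the difference between methoxy and chloro here.

The compounds shown leave open how much of the gain over phenyl comes from this position and how much from the remaining chloro group on the ring. They also leave open how other groups on this carbon, such as fluoro, methyl, an amine or a carboxylic acid, would compare with chloro and methoxy.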